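A few compounds are considered here, and "the series" means these few. Any claim that something is new, unique, unknown or untested is made for them only; others in the source may bear on it.

Measured so far:
- compound 1, `COc1cccc(N2CCN(C(=O)c3oc(C(F)(F)F)nc3-c3cccc(F)c3)CC2)c1`: "not active" (no number reported)
- compound 2, `Cc1nc(-c2cccc(O)c2)c(C(=O)N2CCN(c3cccc(Cl)c3)CC2)o1`: 105 nM
- compound 3, `Cc1nc(-c2ccccc2)c(C(=O)N2CCN(c3c(C)cccc3C)CC2)o1`: 146 nM

Three compounds share a core built around an amide joining a five-membered heteroaromatic ring to a six-membered ring with two nitrogens, which in turn carries an aromatic group. In a functional assay on HL-60 cells (Homo sapiens) for inhibition, read by MTT assay, with a stated time of 72 h (a higher number here means a weaker inhibitor, a lower number a stronger inhibitor), compound 1 gives "not active" (no number reported), so no single number stands for it. In this assay compound 2 gives 105 nM, and compound 3 gives 146 nM. The numbers for compound 2 and compound 3 lie within the usual scatter of each other, so compound 3 stands level with compound 2 among the compounds that have a number at all.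

Compound 4, `Cc1nc(-c2ccccc2)c(C(=O)N2CCN(c3ccc(C(F)(F)F)cc3)CC2)o1`, differs from compound 3 in one place: 4-(trifluoromethyl)phenyl in place of 2,6-dimethylphenyl on an amine nitrogen in a ring. Among the compounds with values here, no measured pair shows the effect of swapping one aromatic group for another on the amine nitrogen in a ring, so the size of the step is uncertain. A modest step toward a weaker inhibitor, around the edge of the scatter, is expected for compound 4, a 1.7-fold higher number from compound 3 to compound 4 (0.23 log units; within the scatter). Compound 4 is estimated at 250 nM, within 80 nM to 900 nM.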

Compound 4, half-maximal inhibitory concentration: > 1000 nM
Compound 4: no number, only a limit; the forecaster's own chance of this, stated with the estimate: 15%; at least 4.0-fold (0.60 log units) between middle value and limit.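

Compound 3 and compound 4 form the only pair shown that differs in one place, and it shows that the aromatic group on the amine nitrogen in a ring is not a free choice: 4-(trifluoromethyl)phenyl in place of 2,6-dimethylphenyl gives an at least 6.8-fold higher number from compound 3 to compound 4 (0.83 log units; beyond the scatter). In this assay compound 4 gives > 1000 nM, a limit of the assay and not a number, so the step has a floor but no known full size: the limit of > 1000 nM in this assay, at which 1 of the 4 values shown sits. The earlier compounds shown here differ from one another in more than one place, so they could not tie a change in this assay to this position alone.

This pair swaps the whole aromatic group, so it cannot say which feature of that group matters. On these data alone, whether a plain phenyl, a 4-chlorophenyl or a 4-methylphenyl on this nitrogen would sit nearer compound 3 or compound 4 stays open.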